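Replacing the 1,3-thiazol-2-yl group of compound 1

The source may report more compounds than this note shows. Statements on the series, on what has been measured and on what is new or still open speak of the compounds shown alone.

Of the compounds shown here, three have so far been measured in a physicochemical assay for solubility (a higher number here means a more soluble compound, a lower number a less soluble compound), and they fall into two groups. Compound 1 (`O=S(=O)(Nc1nccs1)c1ccc2c(c1)OCC[C@H]2c1ccc(C(F)(F)F)cc1-c1nccs1`) gives 7000 nM in this read-out, level with compound 3 (`O=S(=O)(Nc1nccs1)c1ccc2c(c1)OCC[C@@H]2c1ccc(C(F)(F)F)cc1-c1ccc(F)cn1`) at 7000 nM within the usual scatter, and together these two hold the lowest number of the set. Compound 2 (`Cn1nccc1-c1cc(C(F)(F)F)ccc1[C@H]1CCOc2cc(S(=O)(=O)Nc3cccnn3)ccc21`) stands well apart at 915000 nM and lies furthest from compound 1, beyond the scatter.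

The next compound, compound 4 (`O=S(=O)(Nc1nccs1)c1ccc2c(c1)OCC[C@H]2c1ccc(C(F)(F)F)cc1-c1ccc(F)cc1`), keeps the core of compound 1 and alters one group. A 4-fluorophenyl takes the place of the 1,3-thiazol-2-yl on an aromatic carbon, ortho to a large group and meta to a trifluoromethyl group (4-fluorophenyl in place of 1,3-thiazol-2-yl on an aromatic carbon).

Among the measured compounds shown here, no measured pair isolates this change, so the expectation rests on thin ground. Compound 4 is expected to stay close to compound 1 at 7000 nM and not to move toward compound 2 at 915000 nM in this assay overall. The estimated change is a 1.8-fold lower number from compound 1 to compound 4 (0.24 log units; within the scatter) as a small fall that is expected to remain within the scatter. Compound 4 is estimated at 4000 nM with an expected range from 1200 nM to 12000 nM.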

Compound 4, solubility: 147000 nM
The estimate for compound 4 lay 37-fold (1.57 log units) below the measured number; measured number outside the range, above it.
By their numbers in this assay, from the lowest: compounds 1 and 3 (each within the scatter of the next); then compound 4; then compound 2.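

On the aromatic carbon ortho to a large group and meta to a trifluoromethyl group, the group carried there counts for a great deal: with the rest of compound 1 held fixed, 4-fluorophenyl in place of 1,3-thiazol-2-yl gives a 21-fold higher number from compound 1 to compound 4 (1.32 log units; beyond the scatter) in this assay and this is a large step. The earlier compounds shown here could not show this, as none of them formed a pair differing in one place, whereas here a five-membered aromatic ring with hetero atoms gives way to a six-membered aromatic ring of carbon only, and the higher number lies on the side of the carbon-only ring. No measurement at hand bears on why the number moves in this way.

This single pair leaves open whether the step belongs to the ring change or to the fluorine, which a plain phenyl or a 4-fluoropyridine-type ring on the same carbon would help to separate. It also leaves open how an amine such as morpholine or a carboxylic acid would behave at this place, and whether the same swap would give a step of like size on the other sulfonamide groups in the set.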